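Removing the para-methyl from a triazole-linked dibenzyloxy furanone

This account rests on a few compounds, and the source may have more. Where it says the series, first, only, none or still open, it means among the compounds named here.

Compound 1 `Cc1ccc(-c2cn(C/C=C3\OC(=O)C(OCc4ccccc4)=C3OCc3ccccc3)nn2)cc1` is tested in a functional assay on PC-3 cells (Homo sapiens) for antiproliferative activity, read by MTT assay, with a stated time of 24 h; a lower number here means a stronger inhibitor, a higher number a weaker inhibitor. In this assay compound 1 gives only a limit and not a number, > 100000 nM, which is the limit of > 100000 nM in this assay, at which 1 of the 3 values shown sits. Two further members of the series carry a different core: compound 2 `CC(C)(C)c1ccc(-c2cn(CCC3(O)NC(=O)C(OCc4ccccc4)=C3OCc3ccccc3)nn2)cc1` gives 43000 nM in this assay, and compound 3 `CCCCCCCCN1C(=O)C(OCc2ccccc2)=C(OCc2ccccc2)C1(O)CCn1cc(-c2ccccn2)nn1` gives 80300 nM. Compound 4 `O=C1O/C(=C\Cn2cc(-c3ccccc3)nn2)C(OCc2ccccc2)=C1OCc1ccccc1` differs from compound 1 by hydrogen in place of methyl on an aromatic carbon. No measured step of this kind is available among these compounds. The step that the limit leaves unreadable from compound 1 to compound 4 is expected to stay within the usual scatter, with no change in direction. Compound 4 is therefore estimated at 120000 nM, with a range from 50000 nM to 300000 nM.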

Compound 4, half-maximal inhibitory concentration: > 100000 nM
Compound 4: no number, only a limit (the forecaster's own chance of this, stated with the estimate: 60%); the middle value lies beyond the limit too.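

Within the data shown here, compound 1 and compound 4 each give only a limit in this assay and not a number, so no step between them can be read. Going by these compounds, whether the change from 4-methylphenyl to phenyl shifts the response in this assay at all stays open.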